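The source may hold more compounds than are shown below. What is called first, only, known or untested is meant among the compounds shown, and "the series" means these compounds.

For the measured compounds named here, in an ADME assay on Vero cells (Chlorocebus sabaeus) for cytotoxicity, read by MTT assay, with a stated time of 48 h (a higher number here means a weaker inhibitor, a lower number a stronger inhibitor), compound 3 `CS(=O)(=O)NC1CCC(CN2CCN(c3cc(=O)c4cc(C(F)(F)F)cc([N+](=O)[O-])c4s3)CC2)CC1` gives 48.5 ug/mL, the only actual number among the three measured compounds. Compound 1 `Cc1cccc(C(=O)OC2CCC(CN3CCN(c4cc(=O)c5cc(C(F)(F)F)cc([N+](=O)[O-])c5s4)CC3)CC2)c1` reaches only the limit > 64 ug/mL. Compound 2 `CCCC(=O)OC1CCC(CN2CCN(c3cc(=O)c4cc(C(F)(F)F)cc([N+](=O)[O-])c4s3)CC2)CC1` likewise reaches only the limit > 64 ug/mL. The two related steps, an at least 1.3-fold lower number from compound 1 to compound 3 (0.12 log units; that floor lies within the scatter) and an at least 1.3-fold lower number from compound 2 to compound 3 (0.12 log units; that floor lies within the scatter), are therefore floors that lie within the scatter. Compound 4 `C=CC(=O)OC1CCC(CN2CCN(c3cc(=O)c4cc(C(F)(F)F)cc([N+](=O)[O-])c4s3)CC2)CC1` differs from compound 3 by (vinylcarbonyl)oxy in place of methanesulfonamido on a saturated ring carbon. Compound 1 and compound 2 also carry esters on that saturated ring carbon; note (the limit of > 64 ug/mL in this assay, at which 2 of the 3 values shown sit). The step of a 1.3-fold higher number from compound 3 to compound 4 (0.12 log units; within the scatter) is therefore expected to be small, if any, with a readout at or near the limit more likely than not. Compound 4 is estimated at 64 ug/mL, within 40 ug/mL to 100 ug/mL.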

Compound 4, half-maximal inhibitory concentration: > 64 ug/mL
Compound 4 ended at the assay's limit; the forecaster's own chance of this, stated with the estimate: 65%; the middle value sits exactly at the limit.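

In this assay compound 4, a third ester on the saturated ring carbon, gives > 64 ug/mL, a limit and not a number. For the compounds shown here, the only readable step, an at least 1.3-fold higher number from compound 3 to compound 4 (0.12 log units; that floor lies within the scatter), is a floor, so methanesulfonamido and (vinylcarbonyl)oxy are not told apart here, and the steps among the three esters cannot be read. With a small unsaturated ester, the esters shown still all sit at one reading: the limit of > 64 ug/mL in this assay, at which 3 of the 4 values shown sit.

On these data alone, whether any ester differs from another remains open. So does whether an amine or a carboxylic acid on that ring carbon would give a number rather than a limit.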